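Long ester chains reach the cytotoxicity assay's limit

The compounds below may be only part of what the source reports. "The series", "measured", "known", "first", "only" and "open" are said of these compounds alone.

In an ADME assay on HepG2 cells (Homo sapiens) for cytotoxicity, read by neutral red uptake, with a stated time of 24 h (on this read-out lower numbers stand for stronger inhibition and higher numbers for weaker inhibition), the short-chain ester compound 1 `CCCC(=O)Oc1c(C(C)C)cc2c3c1OC(=O)[C@@]31CCCC(C)(C)[C@@H]1CC2` gives 56100 nM as a true number. Compound 2 `CCCCCCCCCCCC(=O)Oc1c(C(C)C)cc2c3c1OC(=O)[C@@]31CCCC(C)(C)[C@@H]1CC2` gives > 1000000 nM which is a limit, not a number. Compound 3 `CCCCCCCCCCCCCCCC(=O)Oc1c(C(C)C)cc2c3c1OC(=O)[C@@]31CCCC(C)(C)[C@@H]1CC2` gives > 1000000 nM and this too is only a limit. Lengthening the chain brought an at least 17-fold higher number from compound 1 to compound 2 (1.25 log units; beyond the scatter) and an at least 17-fold higher number from compound 1 to compound 3 (1.25 log units; beyond the scatter) as large steps, while the long chains themselves offer only a step that the two limits leave unreadable from compound 2 to compound 3 to report. Compound 4 `CCCCCCCC/C=C/CCCCCCCC(=O)Oc1c(C(C)C)cc2c3c1OC(=O)[C@@]31CCCC(C)(C)[C@@H]1CC2` alters the chain of compound 3 with a group of 10 heavy atoms (10 carbon; no ring) in place of a group of 8 heavy atoms (8 carbon; no ring), on a saturated chain carbon, seven bonds along the chain from a carbonyl carbon and adds 1 double bond outside aromatic rings. Since an at least 17-fold higher number from compound 1 to compound 3 (1.25 log units; beyond the scatter) came with lengthening and compound 4 remains long-chained, no step beyond the scatter is expected in this assay here. The expected step is a number no higher from compound 3 to compound 4 (the limit leaves the size open) and no more. For compound 4 the estimated value is 1000000 nM with an expected range of 200000 nM to 2000000 nM and quite possibly only a limit reported.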

Compound 4, half-maximal inhibitory concentration: > 1000000 nM
Compound 4 was reported as a limit (the forecaster's own chance of this, stated with the estimate: 75%); the middle value sits exactly at the limit.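

Within the data shown here, no step to compound 4, whether from compound 2 or from compound 3, can be read in this assay, since all three compounds stand at one limit rather than at a number: the limit of > 1000000 nM in this assay, at which 3 of the 4 values shown sit. Going by these compounds, the true values of compound 2, compound 3 and compound 4 remain open.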